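A few compounds are considered here, and "the series" means these few. Any claim that something is new, unique, unknown or untested is made for them only; others in the source may bear on it.

Measured so far:
- compound 1 `O=C1N(CCC(CCOc2ccc(-c3ccc(Cl)cc3)cc2)Cc2ccccc2)CCN1c1ccncc1`: > 10000 nM
- compound 2 `O=C1N(Cc2cccc(COc3ccc(-c4ccc(Cl)cc4)cc3)c2)CCN1c1ccncc1`: > 6250 nM

In an ADME assay on cells (Homo sapiens) for cytotoxicity (on this read-out higher numbers stand for lower toxicity in this test and lower numbers for higher toxicity in this test), compound 1 gives > 10000 nM, which is a limit and not a number. Compound 2 gives > 6250 nM, also a limit. Within the data shown here, no measured step is therefore available.

The next compound is compound 3 `CC(CCOc1ccc(-c2ccc(Cl)cc2)cc1)CCN1CCN(c2ccncc2)C1=O`. Its difference from compound 1 is hydrogen in place of phenyl on a saturated chain carbon, four bonds along the chain from an amide-type nitrogen in a ring and an oxygen on an aromatic ring. Cut one bond further out, this reads benzyl to methyl.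

The expectation rests on compound 1, whose limit is > 10000 nM. The estimated step that the limit leaves unreadable from compound 1 to compound 3 is expected to stay within the usual scatter, with no firm direction, and another limit is likely. Compound 3 is estimated at 12000 nM, with an expected range of 5000 nM to 30000 nM.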

Compound 3, half-maximal cytotoxic concentration: > 25000 nM
Compound 3 was reported as a limit; the forecaster's own chance of this, stated with the estimate: 75%; at least 2.0-fold (0.31 log units) between middle value and limit.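

In this assay compound 1 and compound 3 are both reported only as limits, and the step between them cannot be read. The compounds shown leave open at what concentration any of them reaches the half-maximal cytotoxic level, and whether replacing phenyl with hydrogen changes it.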